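The source may report more compounds than this note shows. Statements on the series, on what has been measured and on what is new or still open speak of the compounds shown alone.

The set starts from compound 1 `CCCc1ccc(OCc2ccc(C(=O)Nc3ccccc3N)cc2)cc1`, an amide carrying a propyl group on the outer aromatic ring. Among the compounds with values here, in a functional assay on MGC-803 cells (Homo sapiens) for antiproliferative activity, read by CCK-8 assay, with a stated time of 72 h (a higher number here means a weaker inhibitor, a lower number a stronger inhibitor), compound 1 gives 4420 nM, the only single number reported among the three measured entries. Compound 2 `Nc1cnccc1NC(=O)/C=C/c1ccc(COc2ccccc2)cc1`, a different construction with a vinyl amide on a pyridine-type core, reaches only the limit of the assay, at > 32000 nM. Compound 2 therefore sits at the limit of > 32000 nM in this assay, at which 1 of the 3 values shown sits, and supplies no number to compare with. Compound 3 `C/C(=N\O)c1ccc(OCc2ccc(C(=O)NO)cc2)cc1`, a hydroxamic acid bearing an oxime, has in this assay only the entry "not determined" (no result reported), with no single number reported. Compound 1 thus stands as the sole anchor, with nothing measured either stronger or weaker than it to frame it.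

Compound 4 `COc1ccc(OCc2ccc(C(=O)Nc3ccccc3N)cc2)cc1` differs from compound 1 in a single place: methoxy in place of propyl on an aromatic carbon. The change sits on an aromatic carbon of a six-membered aromatic ring of carbon only, para to a large group. Within the data shown here, no measured pair in this set shows what such a swap does, so the expected step is small, in either direction, and not beyond the usual scatter: compound 4 is estimated to show a 1.1-fold higher number from compound 1 to compound 4 (0.05 log units; within the scatter) in this assay relative to compound 1. On that basis compound 4 is expected to give about 5000 nM in this assay, within a range from 1800 nM to 14000 nM.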

Compound 4, half-maximal inhibitory concentration: 3480 nM
Beside the measured number, compound 4's estimate is 1.4-fold (0.16 log units) above it; measured number inside the range.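

In this assay, within the data shown here, the exchange of methoxy for propyl gives the first step in this set that can be read: a 1.3-fold lower number from compound 1 to compound 4 (0.10 log units; within the scatter). At this place, on an aromatic carbon para to a large group, the 4-propylphenyl and 4-methoxyphenyl forms therefore cannot be told apart in this read-out, even though the entering group has one heavy atom fewer, brings in an oxygen and adds a hydrogen-bond acceptor that propyl lacks. Nothing shown here bears on why these two compounds read alike.

The compounds shown leave open whether this position would accept any substituent equally well, as an amine, a carboxylic acid or a longer chain such as hexyl on the same carbon could still move the number beyond the scatter, or could leave it where it is. Going by these compounds, this is also a single pair on a single core in a single cell line, so it remains open whether the same exchange would read the same way on another core or in another assay.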